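From 5-nitrofuran-2-yl to 5-nitrothiophen-2-yl on a shared core

The source may report more compounds than this note shows. Statements on the series, on what has been measured and on what is new or still open speak of the compounds shown alone.

Going by the values given here, in an ADME assay on NIH3T3 cells (Mus musculus) for inhibition, read by sulforhodamine B assay, with a stated time of 48 h (a lower number here means a stronger inhibitor of growth, a higher number a weaker inhibitor of growth), compound 1 `COc1cccc(C(=O)NNC(=O)c2ccc3[nH]c(-c4ccc([N+](=O)[O-])o4)nc3c2)c1` gives 15.6 ug/mL, and its only measured neighbour, compound 2 `COc1ccc(C(=O)NNC(=O)c2ccc3[nH]c(-c4ccc([N+](=O)[O-])o4)nc3c2)cc1OC`, gives 31.3 ug/mL. Among the compounds with values here, the one measured step, a 2.0-fold higher number from compound 1 to compound 2 (0.30 log units; within the scatter), is methoxy in place of hydrogen on an aromatic carbon; it lies within the scatter, so these two values cannot be ranked. Compound 3 `COc1cccc(C(=O)NNC(=O)c2ccc3[nH]c(-c4ccc([N+](=O)[O-])s4)nc3c2)c1` instead carries 5-nitrothiophen-2-yl in place of 5-nitrofuran-2-yl on an aromatic carbon. Within the data shown here, no measured pair tests this swap, and the step of a 2.0-fold higher number from compound 1 to compound 2 (0.30 log units; within the scatter) bears on it only loosely, as a different edit elsewhere in the structure. No step beyond the scatter is therefore expected in this assay, in either direction. The estimated step is a 1.3-fold higher number from compound 1 to compound 3 (0.11 log units; within the scatter). For compound 3 the expected value is 20 ug/mL, with an estimated range from 7 ug/mL to 62.5 ug/mL.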

Compound 3, concentration for 50% growth inhibition: 15.6 ug/mL
Estimate against measurement, compound 3: 1.3-fold (0.11 log units) above; the measured number falls inside the stated range.
By their numbers in this assay, from the lowest: compounds 1, 3 and 2 (each within the scatter of the next).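

In this assay, going by these compounds alone, no change at the digits printed from compound 1 to compound 3 (within the scatter) is the first direct reading at this position, since the earlier step was an edit elsewhere in the structure. On the core of compound 1, a ring sulfur can therefore stand in place of the ring oxygen of the nitro-bearing ring with no readable effect on the number. This holds for this single pair only, and nothing at hand explains the result.

Going by these compounds, it remains open whether the same swap would read the same on the dimethoxy pattern of compound 2. Also open, on these data alone, is whether an amine in place of the nitro group, or a plain phenyl ring in place of the five-membered ring, would leave the number within the scatter.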